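A few compounds are considered here, and "the series" means these few. Any claim that something is new, unique, unknown or untested is made for them only; others in the source may bear on it.

Measured so far:
- compound 1, `N#CCCn1nc(-c2ccc(OCc3cccc(Cl)c3)cc2)oc1=O`: 7400 nM
- compound 2, `Cc1ccc(COc2ccc(-c3nn(CCC#N)c(=S)o3)cc2)cc1`: 10000 nM

In an assay for inhibition of Amine oxidase [flavin-containing] A (Rattus norvegicus) (on this read-out lower numbers stand for stronger inhibition and higher numbers for weaker inhibition), compound 1 gives 7400 nM. In this assay compound 2 gives 10000 nM. Of the two numbers, compound 2 stands at the top, but the gap to compound 1 is within the usual scatter, so the two are not separated by these data.

Compound 3, `N#CCCn1nc(-c2ccc(OCc3ccc([N+](=O)[O-])cc3)cc2)oc1=S`, is the next member and has not yet been measured in this assay. Against compound 2 the difference is nitro in place of methyl on an aromatic carbon, para to a large group, so that the 4-methylphenyl of compound 2 becomes a 4-nitrophenyl. Among the compounds with values here, no pair of measured compounds shows this change, so its size here is not known from the series; the only guide is that compound 1 and compound 2, which differ at several places, give numbers within scatter of one another.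

The step from compound 2 to compound 3 in this assay is expected to be small, a 1.1-fold lower number from compound 2 to compound 3 (0.05 log units; within the scatter), with no clear direction beyond the scatter. Compound 3 is estimated at 9000 nM, within a range of 3000 nM to 30000 nM.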

Compound 3, half-maximal inhibitory concentration: 2600 nM
Compound 3: middle estimate off by 3.5-fold (0.54 log units), on the high side; the whole stated range lies above it.
By their numbers in this assay, from the lowest: compound 3; then compounds 1 and 2 (each within the scatter of the next).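

In this assay, within the data shown here, replacing 4-methylphenyl with 4-nitrophenyl gives a 3.8-fold lower number from compound 2 to compound 3 (0.59 log units; beyond the scatter), the only step so far that changes one place, and it lies beyond the scatter. It shows that the group on this aromatic carbon, para to a large group, is not indifferent in this assay: with the rest of the structure held constant, nitro in place of methyl yields a modest but readable drop in the number, which the earlier pair, differing at several places, could not show. No supporting data are available to explain this step.

One pair cannot show whether the step is particular to nitro or whether another group at the same place, such as an amine, a carboxylic acid or a methoxy group, would give a similar number. Also open, from the compounds shown here alone, is whether the same change would give a step of similar size on the core of compound 1, or with a longer chain in place of the nitrile-bearing one.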